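Swapping a Five-Membered Ring on the Sulfonyl-Bound Carbon

The source may hold more compounds than are shown below. What is called first, only, known or untested is meant among the compounds shown, and "the series" means these compounds.

Measured compounds:
compound 1 `COc1ccc(C2=NOC(c3ccc(C)cc3)C2S(=O)(=O)CC2=NCCO2)cc1`: 65.9%
compound 2 `COc1ccc(C2=NOC(c3ccc(C)cc3)C2S(=O)(=O)CC2=NCCS2)cc1`: 47.5%
compound 3 `O=S(=O)(CC1=NCCS1)C1=NNCC1c1ccc(Cl)cc1`: "not active" (no number reported)

Of the compounds shown here, three have been tested in a functional assay, tested at 50 ug/mL; a higher number here means a stronger effect of the compound at the concentration tested, a lower number a weaker effect. Compound 1 gives 65.9% and compound 2 gives 47.5%. The two share one core and differ only in one place: a group of 5 heavy atoms (3 carbon, 1 nitrogen, 1 oxygen; one five-membered non-aromatic ring with 2 hetero atoms) in place of a group of 5 heavy atoms (3 carbon, 1 nitrogen, 1 sulfur; one five-membered non-aromatic ring with 2 hetero atoms), on a saturated chain carbon bound to a sulfonyl sulfur. This change produces a number 18.4 percentage points higher from compound 2 to compound 1 (beyond the scatter), a step that lies beyond the usual scatter and counts as modest in size.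

Compound 3 is built on a different core. The difference between the two cores is not broken down here. In this assay compound 3 is reported as "not active" (no number reported), with no number attached, so there is no single figure to set against compounds 1 and 2.

Compound 4 `O=S(=O)(CC1=NCCO1)C1=NNCC1c1ccc(Cl)cc1` has not been measured. It differs from compound 3 by a group of 5 heavy atoms (3 carbon, 1 nitrogen, 1 oxygen; one five-membered non-aromatic ring with 2 hetero atoms) in place of a group of 5 heavy atoms (3 carbon, 1 nitrogen, 1 sulfur; one five-membered non-aromatic ring with 2 hetero atoms), on a saturated chain carbon bound to a sulfonyl sulfur. Within the data shown here, this is the same change as the one from compound 2 to compound 1, made at the same place, on the second core.

Among the measured compounds shown here, because a number 18.4 percentage points higher from compound 2 to compound 1 (beyond the scatter) was observed on the first core, some gain on going from compound 3 to compound 4 is expected, but compound 3 starts from no reported activity, and only one example of the change is available, so the expected rise is small and uncertain. For compound 4 in this assay an activity of about 15% is estimated, with a plausible range from 0% to 40%, and a real chance that only "not active" is reported again.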

Compound 4, a percentage reported as activity, at one concentration (the size of the read-out at that concentration, not a potency): "not active" (no number reported)
The entry for compound 4 holds no number; no gap can be computed for the estimate.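

In this assay compound 4, like compound 3, is reported without a number, so no new step can be read from this pair. No available finding bears on this result. The compounds shown leave open whether the same ring swap, which on the core of compound 1 gave a number 18.4 percentage points higher from compound 2 to compound 1 (beyond the scatter), has any measurable effect on the core of compound 3.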